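This account rests on a few compounds, and the source may have more. Where it says the series, first, only, none or still open, it means among the compounds named here.

Measured compounds:
Compound 1, `CCCCn1cc(C2CCN(Cc3cccc(C(=O)O)c3)CC2)c2ccccc21`, gives 275 nM in an assay on isolated protein for inhibition of histamine H1 receptor (Cavia porcellus); a higher number here means a weaker inhibitor, a lower number a stronger inhibitor.
Compound 2, `CCCCn1cc(C2CCN(Cc3ccc(OC)c(C(=O)O)c3)CC2)c2ccccc21`, gives 475 nM in this assay.

Within the data shown here, on these two numbers compound 2 holds the higher one, but the gap to compound 1 is small: the only measured step, a 1.7-fold higher number from compound 1 to compound 2 (0.24 log units; within the scatter), adds a methoxy group to an aromatic carbon and stays within the scatter, so the two compounds cannot be told apart in this assay.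

Compound 3, `COc1ccc(CN2CCC(c3cn(Cc4ccc(Cl)s4)c4ccccc34)CC2)cc1C(=O)O`, has not yet been measured. It differs from compound 2 in one place: 5-chlorothiophen-2-yl in place of propyl on a saturated chain carbon bound to an aromatic nitrogen. Read one bond further out, the change swaps butyl for (5-chlorothiophen-2-yl)methyl. Among the measured compounds shown here, no measured step touches this part of the shared core; the single step known concerns the methoxy group and was within the scatter. There is thus nothing to support a shift in either direction, and the expectation for this assay is a step of no more than the scatter, carried with wide uncertainty. For compound 3 the estimated value is 400 nM, with a range from 100 nM to 1600 nM. This amounts to an expected step of a 1.2-fold lower number from compound 2 to compound 3 (0.07 log units; within the scatter).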

Compound 3, half-maximal inhibitory concentration: 365 nM
Compound 3: the middle estimate sits 1.1-fold (0.04 log units) above what was measured, and the stated range covers the measured number.
By their numbers in this assay, from the lowest: compounds 1, 3 and 2 (each within the scatter of the next).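

Replacing butyl with (5-chlorothiophen-2-yl)methyl is the first change shown at this position on the aromatic nitrogen, and in this assay it gives a 1.3-fold lower number from compound 2 to compound 3 (0.11 log units; within the scatter). A plain saturated chain and a group carrying a five-membered aromatic ring with sulfur and chlorine therefore cannot be told apart here, so for this one pair the position tolerates a clear change in the kind of group without a measurable penalty. No evidence is available that bears on this result.

On these data alone, it remains open whether any group at this position can move the number beyond the scatter, such as a longer chain, a chain ending in an amine or a carboxylic acid, or an unsubstituted thiophen-2-ylmethyl group, which would also separate the part played by the chlorine from that of the ring. Also open, as far as these compounds go, is whether the methoxy group would read the same with the new group in place, a question that would need (5-chlorothiophen-2-yl)methyl on the core of compound 1.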